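The compounds below may be only part of what the source reports. "The series", "measured", "known", "first", "only" and "open" are said of these compounds alone.

Measured compounds in an assay on isolated protein for inhibition of Amine oxidase [flavin-containing] A (Homo sapiens), read by fluorescence, with a stated time of 30 min; on this read-out higher numbers stand for weaker inhibition and lower numbers for stronger inhibition:
- compound 1 `CCN(CCCn1sc2cc(OC)c(OC)cc2c1=O)Cc1ccccc1` gives 9900 nM
- compound 2 `CCN(CCCn1sc2cc(OC)c(OC)cc2c1=O)Cc1ccccc1OC` gives 15500 nM
- compound 3 `COc1cc2sn(CCCCN(C)Cc3ccccc3)c(=O)c2cc1OC` gives 8900 nM

Compounds 1 and 2 differ by methoxy in place of hydrogen on an aromatic carbon, and this change gave a 1.6-fold higher number from compound 1 to compound 2 (0.19 log units; within the scatter). Compound 3 is built from the same atoms as compound 1 joined differently; the difference between the two cores is not broken down here. Compound 4 `COc1ccccc1CN(C)CCCCn1sc2cc(OC)c(OC)cc2c1=O` differs from compound 3 by methoxy in place of hydrogen on an aromatic carbon, the same change as between compounds 1 and 2, with the same surroundings described at the place. Since the earlier step of a 1.6-fold higher number from compound 1 to compound 2 (0.19 log units; within the scatter) stayed within the scatter, a step of comparable size is expected from compound 3 to compound 4, namely a 1.5-fold higher number from compound 3 to compound 4 (0.16 log units; within the scatter). On that basis compound 4 is estimated at 13000 nM in this assay, expected to fall between 6000 nM and 28000 nM.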

Compound 4, half-maximal inhibitory concentration: 7100 nM
Beside the measured number, compound 4's estimate is 1.8-fold (0.26 log units) above it; low and high end bracket the measured number.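

In this assay, going from benzyl to 2-methoxybenzyl gave a 1.3-fold lower number from compound 3 to compound 4 (0.10 log units; within the scatter). Set beside the earlier step, this step does not differ from it: the same change on two cores in this assay, a 1.6-fold higher number (0.19 log units; within the scatter) from compound 1 to compound 2 and a 1.3-fold lower number (0.10 log units; within the scatter) from compound 3 to compound 4, 2.0-fold (0.29 log units) apart, within the scatter of two such steps. This shows that the change carried from one core to the other without a difference that can be told from scatter, but it does not show that methoxy has a real effect on either core, since neither step stands clear of the scatter, and two pairs say nothing about other cores.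

The compounds shown leave open whether a chlorine or a hydroxyl in place of the methoxy would give a step beyond the scatter. They also leave open whether a longer chain carrying the amine would do so.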